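Urea N-aryl variation on a shared thienopyrimidine-thiadiazole series

A few compounds are considered here, and "the series" means these few. Any claim that something is new, unique, unknown or untested is made for them only; others in the source may bear on it.

Two ureas on the shared core have been measured in a functional assay on T47D cells (Homo sapiens) for antiproliferative activity, read by MTT assay, with a stated time of 48 h; on this read-out lower numbers stand for stronger inhibition and higher numbers for weaker inhibition. Compound 1 `O=C(Nc1cccc(C(F)(F)F)c1)Nc1nnc(Sc2ncnc3scc(-c4ccncc4)c23)s1` gives 45100 nM. Compound 2 `Cc1ccc(NC(=O)Nc2nnc(Sc3ncnc4scc(-c5ccncc5)c34)s2)cc1` gives 17800 nM, the lowest of the two numbers; its nearest neighbour is compound 1, and the step of a 2.5-fold lower number from compound 1 to compound 2 (0.40 log units; beyond the scatter) separates them, a modest change for exchanging the whole aryl substituent pattern on the amide-type nitrogen.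

Compound 3 `O=C(Nc1ccc(F)cc1)Nc1nnc(Sc2ncnc3scc(-c4ccncc4)c23)s1` is the next member. Its change from compound 2 is fluoro in place of methyl on an aromatic carbon, para to a large group, so that 4-methylphenyl becomes 4-fluorophenyl.

Among the measured compounds shown here, the only measured step that bears on this position is a 2.5-fold lower number from compound 1 to compound 2 (0.40 log units; beyond the scatter), and it involved a larger exchange of groups than the one-atom swap here. A step of no more than that size is expected, and most likely one that stays within the scatter. Compound 3 is therefore expected to give 20000 nM, with a range from 8000 nM to 50000 nM. This estimate means an expected step of a 1.1-fold higher number from compound 2 to compound 3 (0.05 log units; within the scatter), which does not exceed the usual scatter.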

Compound 3, half-maximal inhibitory concentration: 18900 nM
Beside the measured number, compound 3's estimate is 1.1-fold (0.02 log units) above it; low and high end bracket the measured number.
By their numbers in this assay, from the lowest: compounds 2 and 3 (each within the scatter of the next); then compound 1.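

In this assay, among the compounds shown here, a 1.1-fold higher number from compound 2 to compound 3 (0.03 log units; within the scatter) gives the first direct reading at this position: on an aromatic carbon para to a large group, fluoro in place of methyl produces no step beyond the scatter, so 4-fluorophenyl and 4-methylphenyl cannot be told apart here. The comparison with compound 1 now rests on two aryl groups, and a 2.4-fold lower number from compound 1 to compound 3 (0.38 log units; beyond the scatter) stands alongside a 2.5-fold lower number from compound 1 to compound 2 (0.40 log units; beyond the scatter), so both compound 2 and compound 3 lie beyond the scatter from compound 1, although each step changes the whole aryl substituent pattern. No measurement on these compounds accounts for either the match between methyl and fluoro or the gap to compound 1.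

The compounds shown leave open whether the trifluoromethyl group itself or its place on the phenyl ring sets compound 1 apart, as the group and its place change together in both steps from compound 1. Also open, going by these compounds, is whether a different group at the position held by methyl and fluoro, such as an amine or a carboxylic acid, would shift the number beyond the scatter.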